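Methoxy in place of methyl: expected toxicity step

The source may hold more compounds than are shown below. What is called first, only, known or untested is meant among the compounds shown, and "the series" means these compounds.

Measured in a functional assay on U-251 cells (Homo sapiens) for inhibition, read by MTT assay, with a stated time of 2 days; on this read-out higher numbers stand for lower toxicity in this test and lower numbers for higher toxicity in this test (both values are limits):
- compound 1 `Nc1ccccc1NC(=O)c1ccc(NCC(=O)Nc2cccc([N+](=O)[O-])c2)cc1` gives > 100000 nM
- compound 2 `Cc1ccc(NC(=O)CNc2ccc(C(=O)Nc3ccccc3N)cc2)cc1` gives > 100000 nM

Compound 2 has only a limit (> 100000 nM) and no number. Both measured compounds sit at that same limit (the limit of > 100000 nM in this assay, at which 2 of the 2 values shown sit). Compound 3 `COc1ccc(NC(=O)CNc2ccc(C(=O)Nc3ccccc3N)cc2)cc1` differs from compound 2 by methoxy in place of methyl on an aromatic carbon. Among the compounds with values here, the one measured step, a step that the two limits leave unreadable from compound 1 to compound 2, gives no size to carry over. No step beyond the scatter is therefore expected in this assay, and the estimated step is a number no higher from compound 2 to compound 3 (the limit leaves the size open). For compound 3 the expected value is 100000 nM (estimated range 40000 nM to 200000 nM), probably reported again as a limit.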

Compound 3, concentration lethal to 50% of the cells: > 100000 nM
Compound 3: only a limit was reported; the forecaster's own chance of this, stated with the estimate: 85%; the middle value sits exactly at the limit.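

No new step can be read among compound 1, compound 2 and compound 3, which all stand at one limit: the limit of > 100000 nM in this assay, at which 3 of the 3 values shown sit. In this assay the compounds shown leave open what the change from 4-methylphenyl to 4-methoxyphenyl does to toxicity, if anything.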